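This account rests on a few compounds, and the source may have more. Where it says the series, first, only, none or still open, it means among the compounds named here.

Of the compounds shown here, two have so far been tested in a functional assay (aorta) with Oryctolagus cuniculus as the target; on this read-out lower numbers stand for stronger inhibition and higher numbers for weaker inhibition. Compound 1 `OCc1ccc(-c2nn(Cc3c(F)cccc3F)c3ccccc23)o1` gives 15000 nM in this assay. Compound 2 `CCCc1cnc(-c2nn(Cc3ccccc3F)c3ncccc23)nc1N` gives 252000 nM in this assay, the higher of the two numbers and thus the weaker inhibition; its gap to compound 1 lies beyond the usual scatter of repeated measurements. Compound 3 `N#Cc1cnc(-c2nn(Cc3ccccc3F)c3ncccc23)nc1N` is built from compound 2 by a single change: cyano in place of propyl on an aromatic carbon. Going by the values given here, no measured pair that differs only in this way is available, so there is no directly comparable step to lean on. With nothing to anchor it, the expectation for compound 3 is only a modest shift from the number of compound 2, the direction left open but with a slight lean toward a lower number. The expected step is a 1.7-fold lower number from compound 2 to compound 3 (0.23 log units; within the scatter). Compound 3 is therefore estimated at 150000 nM, within a range from 30000 nM to 600000 nM.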

Compound 3, half-maximal inhibitory concentration: 391000 nM
Estimate against measurement, compound 3: 2.6-fold (0.42 log units) below; the measured number falls inside the stated range.
By their numbers in this assay, from the lowest: compound 1; then compounds 2 and 3 (each within the scatter of the next).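

Replacing propyl with cyano on this aromatic carbon, ortho to an amino group, gives a 1.6-fold higher number from compound 2 to compound 3 (0.19 log units; within the scatter) in this assay, so this pair does not separate the two groups on this read-out. The change swaps a group with no hydrogen-bond acceptor for one that carries a hydrogen-bond acceptor, yet the two numbers stay within the ordinary variation between repeat measurements. No measurement at hand explains why the two groups read alike here.

With only these two groups shown at this position, it remains open whether any group on this carbon can move the number beyond that variation. A methoxy group, a dimethylamino group or a carboxylic acid on the same carbon would test whether the position responds at all, and a longer chain such as hexyl would extend the propyl side.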